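The source may report more compounds than this note shows. Statements on the series, on what has been measured and on what is new or still open speak of the compounds shown alone.

Measured in an ADME assay on WI-38 cells (Homo sapiens) for cytotoxicity, read by MTT assay, with a stated time of 72 h; on this read-out lower numbers stand for stronger inhibition and higher numbers for weaker inhibition:
- compound 1 `CC(C)(C)c1ccc(NC(=O)CCc2cccc3c2B(O)OC3)cc1`: 55000 nM
- compound 2 `COc1ccc(NC(=O)CCc2cccc3c2B(O)OC3)cc1`: > 100000 nM
- compound 3 `CCOC(=O)c1ccc(NC(=O)CCc2cccc3c2B(O)OC3)cc1`: > 100000 nM

Only compound 1 has a true number here. Compound 2 gives a limit, not a number. On these data alone, compound 3 also gives only a limit, > 100000 nM, so its real value is unknown. The wider picture is the limit of > 100000 nM in this assay, at which 2 of the 3 values shown sit.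

Compound 4 `O=C(CCc1cccc2c1B(O)OC2)Nc1ccc([N+](=O)[O-])cc1` differs from compound 3 as follows: nitro in place of ethoxycarbonyl on an aromatic carbon. In words, nitro replaces ethoxycarbonyl on an aromatic carbon.

The closest measured swaps are at the same place on the ring. One is an at least 1.8-fold higher number from compound 1 to compound 2 (0.25 log units; that floor lies within the scatter). Another is an at least 1.8-fold higher number from compound 1 to compound 3 (0.25 log units; that floor lies within the scatter). The third is a step that the two limits leave unreadable from compound 2 to compound 3. None of them shows a change beyond the scatter, so they give no ground for expecting a real shift in this assay.

The expected step is therefore none beyond the scatter: a number no higher from compound 3 to compound 4 (the limit leaves the size open). For compound 4 the estimate is 100000 nM, with an expected range from 45000 nM to 200000 nM, and a report as a limit alone is likely.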

Compound 4, half-maximal inhibitory concentration: > 100000 nM
Compound 4 gave a limit, no number (the forecaster's own chance of this, stated with the estimate: 70%); the middle value sits exactly at the limit.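

In this assay, compound 4 gives > 100000 nM, which is a limit and not a number. Nitro is therefore a third group on this aromatic carbon, after methoxy and ethoxycarbonyl, that yields no true value, and compound 1 with its tert-butyl remains the only one that goes against this pattern. The one readable step is an at least 1.8-fold higher number from compound 1 to compound 4 (0.25 log units; that floor lies within the scatter), so even this swap shows no change beyond the scatter, the steps to compound 4 from compound 2 and compound 3 cannot be read, and the picture now gathers at a single point: the limit of > 100000 nM in this assay, at which 3 of the 4 values shown sit.

On these data alone, the true values of compound 2, compound 3 and compound 4 stay unknown, so no order among them can be drawn. Also open, as far as these compounds go, is whether an amine or a carboxylic acid on this aromatic carbon would give a true number in this assay.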